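The source may report more compounds than this note shows. Statements on the series, on what has been measured and on what is new or still open speak of the compounds shown alone.

Working notes on the series, all measured in a functional assay on SEM cells (Homo sapiens) for cytotoxicity, with a stated time of 72 h; on this read-out lower numbers stand for an effect already at smaller amounts and higher numbers for an effect only at larger amounts of compound:

- compound 1 `C=C[C@@](C)(/C=C/c1ccc(OCc2ccccc2)cc1)CCC=C(C)C`: > 36600 nM
- compound 2 `C=C[C@@](C)(/C=C/c1ccc(OS(=O)(=O)C(F)(F)F)cc1)CCC=C(C)C`: > 36600 nM
- compound 3 `C=C[C@@](C)(/C=C/c1ccc(Nc2ccc(Cl)cc2)cc1)CCC=C(C)C`: > 36600 nM

Each of these three entries is a limit and not a number. Compound 3 stands at the limit of > 36600 nM in this assay, at which 3 of the 3 values shown sit, so it cannot be placed relative to compound 1 or compound 2.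

The next compound is compound 4 `C=C[C@@](C)(/C=C/c1ccc(-c2ccccc2)cc1)CCC=C(C)C`. The change is phenyl in place of (4-chlorophenyl)amino on an aromatic carbon, which puts phenyl in place of (4-chlorophenyl)amino on an aromatic carbon.

Within the data shown here, three measured steps bear on this change, as all of them exchange the group at that place on the shared core. They are a step that the two limits leave unreadable from compound 1 to compound 2, a step that the two limits leave unreadable from compound 1 to compound 3 and a step that the two limits leave unreadable from compound 2 to compound 3. None of them has a readable size, and none gives a direction.

Three different groups at this place have so far all ended at the limit, and this holds only for these compounds. Compound 4 is therefore expected to stay at or close to that limit in this assay, with no step beyond the scatter in either direction. The step expected is a number no higher from compound 3 to compound 4 (the limit leaves the size open). The estimated value for compound 4 is 36600 nM, with an expected range from 12000 nM to 50000 nM.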

Compound 4, half-maximal effective concentration: > 36600 nM
Compound 4 gave a limit, no number; the forecaster's own chance of this, stated with the estimate: 80%; the middle value lies on the limit itself.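

In this assay, compound 4 gives a limit and not a number, as do compound 1, compound 2 and compound 3, so none of the steps to compound 4 can be read. All four compounds sit at the same limit: the limit of > 36600 nM in this assay, at which 4 of the 4 values shown sit.

The compounds shown leave open whether any group at this place on the shared core gives a measurable value, and how these four groups would rank.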